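The source may report more compounds than this note shows. Statements on the series, on what has been measured and on what is new or still open speak of the compounds shown alone.

Measured so far:
- compound 1, `O=c1cc(CSC(=S)N2CCCCC2)oc2ccccc12`: > 25000 nM
- compound 2, `COc1ccc2oc(CSC(=S)N3CCCCC3)cc(=O)c2c1`: 5000 nM
- compound 3, `COc1ccc2occ(CSC(=S)N3CCCCC3)c(=O)c2c1`: 4700 nM

All three were tested in a functional assay on LM7 cells (Homo sapiens) for antiproliferative activity, read by MTT assay, with a stated time of 72 h; on this read-out lower numbers stand for stronger inhibition and higher numbers for weaker inhibition. For compound 1 the value recorded in this assay is a limit of the assay rather than a number, > 25000 nM. Compound 2 gives 5000 nM in this assay, and compound 3 gives 4700 nM; these two values lie within the scatter of each other, so no order between them can be read. Compound 2 and compound 3 carry the same atoms joined differently; how the two cores differ is not broken down here.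

For the measured compounds named here, the one measured step is the change (hydrogen in place of methoxy on an aromatic carbon), which gave an at least 5.0-fold higher number from compound 2 to compound 1 (0.69 log units; beyond the scatter). The step runs into (the limit of > 25000 nM in this assay, at which 1 of the 3 values shown sits), so its full size is not known, only its floor.

Compound 4, `O=c1c(CSC(=S)N2CCCCC2)coc2ccccc12`, has not yet been measured. It arises from compound 3 by hydrogen in place of methoxy on an aromatic carbon, the same change that carries compound 2 to compound 1, and the surroundings of the place are the same word for word. The step from compound 3 to compound 4 in this assay is therefore expected to be of the order of a 5.3-fold higher number from compound 3 to compound 4 (0.73 log units; beyond the scatter). This expectation rests on the measured step of an at least 5.0-fold higher number from compound 2 to compound 1 (0.69 log units; beyond the scatter). Compound 4 is accordingly estimated at 25000 nM, with a range of 12000 nM to 60000 nM, and a good chance that this assay again returns only a limit.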

Compound 4, half-maximal inhibitory concentration: 4600 nM
Beside the measured number, compound 4's estimate is 5.4-fold (0.74 log units) above it; measured number outside the range, below it.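

In this assay, hydrogen in place of methoxy on an aromatic carbon gives a 1.0-fold lower number from compound 3 to compound 4 (0.01 log units; within the scatter), so on the core of compound 3 the methoxy can be lost without a readable change, and the step does not carry over from the core of compound 2 at the same size: the same change on two cores in this assay, an at least 5.0-fold higher number (0.69 log units; beyond the scatter) from compound 2 to compound 1 and a 1.0-fold lower number (0.01 log units; within the scatter) from compound 3 to compound 4, at least 5.1-fold (0.70 log units) apart, beyond the scatter of two such steps The step on the core of compound 2 and the gap between the two steps are floors only, since compound 1 stands at a limit of the assay and not at a number: the limit of > 25000 nM in this assay, at which 1 of the 4 values shown sits. This is one matched pair on each of two cores, so it shows that the outcome of this change depends on the core here, but it does not show why, and it gives no rule for any other core or any other group.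

Open, on these data alone, is whether another group on that aromatic carbon, such as ethoxy, chlorine or an amine, would split the two cores as methoxy does. Also open, as far as these compounds go, is whether the split persists when the side chain carrying the sulfur atoms gives way to a carboxylic acid or a longer chain.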